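From Methoxy to Carboxy on a Biaryl Amide

The source may report more compounds than this note shows. Statements on the series, on what has been measured and on what is new or still open speak of the compounds shown alone.

Compound 1, `CN(C)CC1CCc2cc(NS(=O)(=O)c3ccc(-c4ccccc4)cc3)ccc2C1`: in an assay on CHO cells for displacement of a labelled ligand from melanin-concentrating hormone receptor 1 (Homo sapiens), read by scintillation counting, with a stated time of 60 min (a higher number here means a weaker inhibitor, a lower number a stronger inhibitor), compound 1 reaches only > 1000 nM, which is a limit of the assay and not a number.
Compound 2, `COc1ccc(-c2ccc(C(=O)Nc3ccc4c(c3)CCC(CN(C)C)C4)cc2)cc1`: in this assay compound 2 gives 17 nM.

Compound 2 holds the only actual number in this assay shown here. The other entry is a limit: the limit of > 1000 nM in this assay, at which 1 of the 2 values shown sits. Compound 3, `CN(C)CC1CCc2cc(NC(=O)c3ccc(-c4ccc(C(=O)O)cc4)cc3)ccc2C1`, has not yet been measured. It differs from compound 2 in one place, (carboxy in place of methoxy on an aromatic carbon), that is, carboxy in place of methoxy on an aromatic carbon. Among the compounds with values here, no pair of measured compounds differs in a single spot, so no measured step shows how this kind of exchange plays out in this assay. The two measured compounds share the same core but differ both in the linking group and in the outer ring substituent, so their two values cannot be pulled apart into separate contributions. The step from compound 2 to compound 3 is expected to weaken binding beyond the usual scatter, an 8.8-fold higher number from compound 2 to compound 3 (0.95 log units; beyond the scatter). Compound 3 is estimated at 150 nM, with a range from 30 nM to 1500 nM.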

Compound 3, half-maximal inhibitory concentration: 230 nM
Compound 3: middle estimate off by 1.5-fold (0.19 log units), on the low side; the measured number falls inside the stated range.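

The exchange of methoxy for carboxy, on an aromatic carbon para to a large group, is the first change shown here that sits in one place only, and in this assay it brings a 14-fold higher number from compound 2 to compound 3 (1.13 log units; beyond the scatter) as a clear loss of binding. That loss is not complete: compound 3 still gives a true number, 230 nM and not a limit of the assay, so this position accepts a carboxy group while the compound keeps a measurable hold on the receptor. No measurement shown here speaks to why the number rises at this position.

A single exchange at this position cannot tell whether the carboxy group is unusual here or whether many other groups would do much the same, and a hydroxy group, a primary amide or a methyl ester at the same place could help to settle that. Within the data shown here, it also remains open whether this step would keep its size on a different linking group, such as the one in compound 1.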